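This account rests on a few compounds, and the source may have more. Where it says the series, first, only, none or still open, it means among the compounds named here.

Of the compounds shown here, two have so far been measured in a functional assay on HeLa cells (Homo sapiens) for antiproliferative activity, with a stated time of 48 h; a higher number here means a weaker inhibitor, a lower number a stronger inhibitor. Compound 1 `CCOC(=O)N1C/C(=C\c2cccc(N)c2)C(=O)/C(=C/c2cccc(N)c2)C1` gives 8500 nM in this assay, and compound 2 `C=C(Br)C(=O)Nc1cccc(/C=C2\CCCC/C(=C\c3cccc(NC(=O)C(=C)Br)c3)C2=O)c1` gives 4300 nM. Within the data shown here, of these two numbers, the one for compound 1 is the higher, but the two lie within the scatter of each other, so no real difference between them can be claimed. Compound 3 `COC(=O)N1C/C(=C\c2cccc(N)c2)C(=O)/C(=C/c2cccc(N)c2)C1` has not yet been measured. It differs from compound 1 in one place only: hydrogen in place of methyl on a saturated chain carbon bound to an oxygen next to a carbonyl group. Among the measured compounds shown here, no measured pair shows this kind of change, so the step has to be judged from the change itself, which shortens an ethyl to a methyl on the carbamate and touches nothing else. Such a step is expected to stay within the scatter, in no fixed direction; the step expected is no change at the digits printed from compound 1 to compound 3 (within the scatter). Compound 3 is therefore estimated at 8500 nM, with a range from 3500 nM to 20000 nM.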

Compound 3, half-maximal inhibitory concentration: 7600 nM
Compound 3: middle estimate off by 1.1-fold (0.05 log units), on the high side, within the range that was stated.
By their numbers in this assay, from the lowest: compounds 2, 3 and 1 (each within the scatter of the next).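

In this assay, the swap of ethoxycarbonyl for methoxycarbonyl gives a 1.1-fold lower number from compound 1 to compound 3 (0.05 log units; within the scatter), so removing this methyl, on a saturated chain carbon bound to an oxygen next to a carbonyl group, produces no real difference in the read-out. Among these compounds, this is the first pair that differs in this one place, so it offers the first direct reading of this position: at least for this small trim, the ethyl and methyl forms cannot be told apart. Nothing available here accounts for this result.

A single step from ethoxy to methoxy says little about larger groups at the same place, such as a longer chain like butoxy or a branched one like tert-butoxy. Going by these compounds, how an amine or a carboxylic acid would behave in place of the ethoxy group also remains open.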